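Hydroxymethyl variant: compound 3

The source may report more compounds than this note shows. Statements on the series, on what has been measured and on what is new or still open speak of the compounds shown alone.

Measured so far:
compound 1 `CCCCN(c1nc2c(C(=O)NC)cccc2o1)[C@H](C)c1ccc(-c2ccccc2-c2nnn[nH]2)cc1` — 0.000975
compound 2 `CCCCN(c1nc2c(-c3nccn3C)cccc2o1)[C@H](C)c1ccc(-c2ccccc2-c2nnn[nH]2)cc1` — 0.00299

In an ADME assay on the whole organism (plasma, Macaca fascicularis) for protein binding, read by LC-MS, using equilibrium dialysis and cassette dosing, with a stated time of 24 h, at a dose of 1 mg/kg by the oral route (a higher number here means a larger unbound share of the compound, a lower number a smaller unbound share), compound 2 stands highest of the two numbers; its nearest neighbour is compound 1, separated by a 3.1-fold higher number from compound 1 to compound 2 (0.49 log units; beyond the scatter). Compound 3 `CCCCN(c1nc2c(CO)cccc2o1)[C@H](C)c1ccc(-c2ccccc2-c2nnn[nH]2)cc1` differs from compound 2 by hydroxymethyl in place of 1-methyl-1H-imidazol-2-yl on an aromatic carbon. For the measured compounds named here, only the step from compound 1 to compound 2 bears on this position, and it was modest; the ring it introduced now leaves again and a hydroxymethyl enters instead. A downward step in this assay of roughly that size is therefore expected, a 2.3-fold lower number from compound 2 to compound 3 (0.36 log units; beyond the scatter). Compound 3 is expected to give 0.0013, in the range 0.0005 to 0.0035.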

Compound 3, unbound fraction: 0.00112
Estimate against measurement, compound 3: 1.2-fold (0.06 log units) above; low and high end bracket the measured number.
By their numbers in this assay, from the lowest: compounds 1 and 3 (each within the scatter of the next); then compound 2.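

In this assay, the unbound fraction seen with 1-methyl-1H-imidazol-2-yl does not carry over to hydroxymethyl on this aromatic carbon (a 2.7-fold lower number from compound 2 to compound 3 (0.43 log units; beyond the scatter)). Hydroxymethyl and methylcarbamoyl are not separated here (a 1.1-fold higher number from compound 1 to compound 3 (0.06 log units; within the scatter)), so of the three groups only 1-methyl-1H-imidazol-2-yl stands apart. No evidence on the cause of this difference is available.

As far as these compounds go, whether another aromatic ring, such as pyridine, would stand with compound 2 remains open. The same holds for an amine or a carboxylic acid on this carbon.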